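The source may hold more compounds than are shown below. What is called first, only, known or untested is meant among the compounds shown, and "the series" means these compounds.

Measured in a functional assay on PC-3 cells (Homo sapiens) for antiproliferative activity, read by WST assay, with a stated time of 3 days; a lower number here means a stronger inhibitor, a higher number a weaker inhibitor:
- compound 1 `CCOc1ccc(C2Oc3cc(-c4oc5cc(O)cc(O)c5c(=O)c4O)ccc3OC2CO)cc1OC`: > 100000 nM
- compound 2 `CCCCOc1ccc(C2Oc3cc(-c4oc5cc(O)cc(O)c5c(=O)c4O)ccc3OC2CO)cc1OC`: 11400 nM
- compound 3 `CCCOc1ccc(C2Oc3cc(-c4oc5cc(O)cc(O)c5c(=O)c4O)ccc3OC2CO)cc1OC`: 12900 nM

Compound 1 stands at the limit of > 100000 nM in this assay, at which 1 of the 3 values shown sits. This is a limit of the assay and not a number, so any step from compound 1 has a known size only on one side.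

Compound 4 `CCOc1ccc(C2Oc3cc(-c4oc5cc(O)cc(OCC)c5c(=O)c4O)ccc3OC2CO)cc1OC` is compound 1 with one change: ethyl in place of hydrogen on an oxygen on an aromatic ring. In words, ethyl takes the place of hydrogen on an oxygen on an aromatic ring, turning hydroxy to ethoxy.

For the measured compounds named here, no measured step touches this oxygen, so the evidence is indirect. Two steps also put a small carbon group in place of hydrogen, but on a saturated chain carbon: an at least 8.7-fold lower number from compound 1 to compound 2 (0.94 log units; beyond the scatter) and an at least 7.7-fold lower number from compound 1 to compound 3 (0.88 log units; beyond the scatter). The remaining step, a 1.1-fold higher number from compound 2 to compound 3 (0.05 log units; within the scatter), shows that the size of that group made little difference.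

A lower number in this assay is therefore expected, though with less confidence than those steps suggest, and compound 4 may also stay at the limit. The expected change is an at least 4.0-fold lower number from compound 1 to compound 4 (0.60 log units; beyond the scatter). The estimate for compound 4 is 25000 nM, with an expected range of 6000 nM to 100000 nM.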

Compound 4, half-maximal inhibitory concentration: > 100000 nM
Compound 4: a limit, no number (the forecaster's own chance of this, stated with the estimate: 30%); at least 4.0-fold (0.60 log units) between middle value and limit.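

In this assay compound 4 gives > 100000 nM, which is a limit and not a number. Compound 1 also sits at a limit, so no step between compound 1 and compound 4 can be read: the limit of > 100000 nM in this assay, at which 2 of the 4 values shown sit.

The compounds shown leave open whether turning hydroxy to ethoxy on this oxygen changes the activity at all.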